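A few compounds are considered here, and "the series" means these few. Any claim that something is new, unique, unknown or untested is made for them only; others in the source may bear on it.

Compound 1, `CC[C@@H]1C(=O)N(C)c2cnc(-n3ccc4cc(F)ccc43)nc2N1C1CCCC1`: "not active" (no number reported)
Compound 2, `CCCCNS(=O)(=O)c1ccc(Nc2ncc3c(n2)N(c2ccn(C)n2)C(CC)C(=O)N3C)cc1`: 5780 nM
Compound 3, `CC[C@@H]1C(=O)N(C)c2cnc(-n3ccc4cc(C(=O)NC)ccc43)nc2N1C1CCCC1`: 1000 nM

Three compounds were tested in a functional assay on MCF7 cells (Homo sapiens) for antiproliferative activity, read by CCK-8 assay, with a stated time of 72 h (a higher number here means a weaker inhibitor of growth, a lower number a stronger inhibitor of growth), but only two of them returned a number. Compound 1 is recorded as "not active" (no number reported) without a figure. Compound 2 gives 5780 nM, which is the higher of the two numbers; compound 3 gives 1000 nM, a lower number, and the gap between compound 2 and compound 3 lies beyond the scatter of repeated measurements. These two compounds differ in several places at once, so the gap cannot be traced to any single change.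

Compound 4, `CCC1C(=O)N(C)c2cnc(Nc3ccc(S(=O)(=O)NC)cc3)nc2N1c1ccn(C)n1`, has not yet been measured in this assay. It differs from compound 2 in one place only: hydrogen in place of propyl on a saturated chain carbon bound to a sulfonamide nitrogen. Among the measured compounds shown here, no measured pair of compounds shows this change, so there is nothing in the present numbers to say which way it should move. The expectation for compound 4 is therefore a step from compound 2 of about a 1.0-fold higher number from compound 2 to compound 4 (0.02 log units; within the scatter), that is, none beyond the scatter. On that basis compound 4 is estimated at 6000 nM in this assay, with a range from 2000 nM to 20000 nM.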

Compound 4, concentration for 50% growth inhibition: 3750 nM
Estimate against measurement, compound 4: 1.6-fold (0.20 log units) above; the range from low to high includes it.
By their numbers in this assay, from the lowest: compound 3; then compounds 4 and 2 (each within the scatter of the next).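

In this assay, among the compounds shown here, the exchange of butylsulfamoyl for methylsulfamoyl gives a 1.5-fold lower number from compound 2 to compound 4 (0.19 log units; within the scatter) and so is the first change here that can be read at a single place; the earlier compounds offered only a gap across several differences at once. It shows that, in this one pair, hydrogen can stand in place of propyl on a saturated chain carbon bound to a sulfonamide nitrogen without a difference that can be told from the scatter, so the three carbons that leave make no measurable mark on growth inhibition on the core of compound 2. Nothing measured here offers a reason for this result.

A single pair cannot say whether the same holds on other cores, and it tests only butyl and methyl at this place. On these data alone, what an amine or a carboxylic acid carried on that chain would do, or a chain longer than butyl, or a ring in its stead, remains open, as does the sulfonamide with no carbon chain on its nitrogen at all.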